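Bromo to fluoro on the aromatic ring: expected effect

The source may hold more compounds than are shown below. What is called first, only, known or untested is meant among the compounds shown, and "the series" means these compounds.

Measured in a functional assay on HEp-2 cells (Homo sapiens) for cytotoxicity, read by MTT assay, with a stated time of 72 h, tested at 2.5 ug/mL; on this read-out higher numbers stand for more inhibition of growth at the one concentration tested and lower numbers for less inhibition of growth:
compound 1 `O=C1NC(=S)/C(=C/c2ccc(Cl)cc2)S1` gives 3.91%
compound 2 `O=C1NC(=S)/C(=C/c2ccccc2Br)S1` gives 10.3%

Compound 2 stands with a number that differs from that of compound 1 by a gap within the scatter, so the two values show no separation. Compound 3 `O=C1NC(=S)/C(=C/c2ccccc2F)S1` differs from compound 2 by fluoro in place of bromo on an aromatic carbon. Among the measured compounds shown here, no step between measured compounds is available for this swap, so its size is untested; the expectation is no step beyond the scatter in this assay. For compound 3 the estimate is 7%, with a range from -5% to 20%, which means an expected step of a number 3.3 percentage points lower from compound 2 to compound 3 (within the scatter).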

Compound 3, percent growth inhibition at one concentration: 1.66%
Beside the measured number, compound 3's estimate is 5.3 percentage points above it; the range from low to high includes it.
By their numbers in this assay, from the lowest: compounds 3, 1 and 2 (each within the scatter of the next).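

In this assay, among the compounds shown here, fluoro in place of bromo on this aromatic carbon gives a number 8.6 percentage points lower from compound 2 to compound 3 (within the scatter), the first direct reading of a change at this position. This single halogen swap therefore shows no separation between the two groups here. Nothing available bears on a reason for this result.

Going by these compounds, whether an amine or a carboxylic acid on this aromatic carbon would give a step beyond the scatter remains open. So does whether the same swap would read alike at another place on the ring.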